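Aryl swap on a triazole-linked bicyclic lactam

This account rests on a few compounds, and the source may have more. Where it says the series, first, only, none or still open, it means among the compounds named here.

Compound 1 `COc1ccccc1-n1cc(CN2C(=O)C[C@@H]3CC[C@@]2(C)C3(C)C)nn1`: in a functional assay on PANC-1 cells (Homo sapiens) for inhibition, read by MTT assay, with a stated time of 24 h (on this read-out lower numbers stand for stronger inhibition and higher numbers for weaker inhibition), compound 1 gives 120 nM.
Compound 2 `Cc1ccc(-n2cc(CN3C(=O)C[C@@H]4CC[C@@]3(C)C4(C)C)nn2)cc1`: in this assay compound 2 gives 270 nM.
Compound 3 `CC1(C)[C@H]2CC[C@]1(C)N(Cc1cn(-c3ccccc3Cl)nn1)C(=O)C2`: in this assay compound 3 gives 270 nM.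

Compound 2 and compound 3 stand level at the digits shown, together the highest of the three numbers; compound 1 sits lower, with a 2.3-fold higher number from compound 1 to compound 2 (0.35 log units; beyond the scatter) and a 2.3-fold higher number from compound 1 to compound 3 (0.35 log units; beyond the scatter) both beyond the scatter, while no change at the digits printed from compound 2 to compound 3 (within the scatter) lies within it. Compound 4 `CC1(C)[C@H]2CC[C@]1(C)N(Cc1cn(-c3cccc(F)c3)nn1)C(=O)C2` has not been measured. Its change from compound 2: 3-fluorophenyl in place of 4-methylphenyl on an aromatic nitrogen. Within the data shown here, no measured step brings in a 3-fluorophenyl, so only the three steps seen give guidance: two aryl swaps moved the number modestly, one not at all. The expected step in this assay is therefore small, in either direction, possibly none beyond the scatter: a 1.1-fold lower number from compound 2 to compound 4 (0.03 log units; within the scatter). Compound 4 is estimated at 250 nM, within 110 nM to 550 nM.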

Compound 4, half-maximal inhibitory concentration: 220 nM
Beside the measured number, compound 4's estimate is 1.1-fold (0.06 log units) above it, and the stated range covers the measured number.
By their numbers in this assay, from the lowest: compounds 1, 4, 2 and 3 (each within the scatter of the next, the first and the last beyond it).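

With 3-fluorophenyl on the aromatic nitrogen, the readings are a 1.2-fold lower number from compound 2 to compound 4 (0.09 log units; within the scatter) and a 1.2-fold lower number from compound 3 to compound 4 (0.09 log units; within the scatter) and a 1.8-fold higher number from compound 1 to compound 4 (0.26 log units; within the scatter), all within the scatter. Compound 4 therefore sits level with each earlier compound, including compound 1, which stood clearly apart from compounds 2 and 3. Nothing measured here gives a reason for these numbers.

The compounds shown leave open how this position responds to groups other than a substituted phenyl, such as a pyridine ring, or to a phenyl ring carrying an amine or a carboxylic acid.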